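This account rests on a few compounds, and the source may have more. Where it says the series, first, only, none or still open, it means among the compounds named here.

Measured compounds in an assay on isolated protein for displacement of a labelled ligand from melanin-concentrating hormone receptor 1 (Homo sapiens); a lower number here means a stronger inhibitor, a higher number a weaker inhibitor:
- compound 1, `CCCc1ccc(/C=C/C(=O)Nc2ccc3nc(CCC)cc(N)c3c2)cc1`: 4 nM
- compound 2, `CCCc1cc(N)c2cc(NC(=O)/C=C/c3ccc(Br)cc3)ccc2n1`: 4 nM
- compound 3, `CCCc1cc(N)c2cc(NC(=O)/C=C/c3ccc(C(C)C)cc3)ccc2n1`: 2.9 nM

All three share one core and differ only in the group on the outer six-membered carbon ring. The numbers sit close together: no change at the digits printed from compound 1 to compound 2 (within the scatter), a 1.4-fold lower number from compound 1 to compound 3 (0.14 log units; within the scatter), and a 1.4-fold lower number from compound 2 to compound 3 (0.14 log units; within the scatter). Compound 3 holds the smallest of the three figures, but each of its steps to compound 1 and to compound 2 is within the scatter, so the three substituents — propyl, bromo, isopropyl — cannot be told apart in this assay on these data.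

Compound 4, `CCCCc1ccc(/C=C/C(=O)Nc2ccc3nc(CCC)cc(N)c3c2)cc1`, continues the same variation: butyl in place of isopropyl on an aromatic carbon. Going by the values given here, the steps that bear on it are the exchanges among propyl, bromo and isopropyl at this position, none of which moved the number beyond the scatter. A butyl chain at the same place is therefore expected to leave this assay essentially unchanged, with a 1.2-fold higher number from compound 3 to compound 4 (0.08 log units; within the scatter) as the expected step. The estimate for compound 4 is 3.5 nM, with a range from 1.5 nM to 8 nM.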

Compound 4, half-maximal inhibitory concentration: 45 nM
Estimate against measurement, compound 4: 13-fold (1.11 log units) below, and the stated range ends below it.
By their numbers in this assay, from the lowest: compounds 3, 1 and 2 (each within the scatter of the next); then compound 4.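

In this assay, going by these compounds alone, this position proves less tolerant than the earlier compounds suggested: the change to butyl gives a 16-fold higher number from compound 3 to compound 4 (1.19 log units; beyond the scatter), and an 11-fold higher number from compound 2 to compound 4 (1.05 log units; beyond the scatter), so the flat picture across propyl, bromo and isopropyl does not extend to butyl. The cleanest comparison is the single added methyl on the saturated chain, three bonds along from an aromatic carbon, which gives an 11-fold higher number from compound 1 to compound 4 (1.05 log units; beyond the scatter), showing that one extra chain carbon is enough to separate butyl from propyl. Nothing available explains this jump.

Going by these compounds, whether a longer chain such as pentyl moves the number further or leaves it near that of compound 4 remains open. Also open, on these data alone, is whether a branched tert-butyl group or a propoxy chain at the same place follows isopropyl or butyl.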